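Changing the aromatic group on a carbonyl carbon

This account rests on a few compounds, and the source may have more. Where it says the series, first, only, none or still open, it means among the compounds named here.

Measured so far in a functional assay on MCF7 cells (Homo sapiens) for antiproliferative activity, read by MTT assay, with a stated time of 72 h (a higher number here means a weaker inhibitor, a lower number a stronger inhibitor), for this series:
- compound 1 `COc1ccc(C(=O)O[C@H]2CC[C@]3(C)[C@H](CC[C@@](C)(O)[C@H]3CC[C@@H]3C(C)=CC[C@H]4[C@H](CC[C@]4(C)O)C3(C)C)OC2(C)C)cc1` (41700 nM)
- compound 2 `CC1=CC[C@H]2[C@H](CC[C@]2(C)O)C(C)(C)[C@@H]1CC[C@H]1[C@]2(C)CC[C@H](OC(=O)c3cccc(C(F)(F)F)c3)C(C)(C)O[C@H]2CC[C@@]1(C)O` (37900 nM)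

Compound 2 (37900 nM) stands level with compound 1 (41700 nM) on these numbers, with the two values within the scatter of each other. The next compound to be tested is compound 3 `CC1=CC[C@H]2[C@H](CC[C@]2(C)O)C(C)(C)[C@@H]1CC[C@H]1[C@]2(C)CC[C@H](OC(=O)c3ccccc3[N+](=O)[O-])C(C)(C)O[C@H]2CC[C@@]1(C)O` and it differs from compound 2 by one change: 2-nitrophenyl in place of 3-(trifluoromethyl)phenyl on a carbonyl carbon and thus 2-nitrophenyl in place of 3-(trifluoromethyl)phenyl on a carbonyl carbon.

Going by the values given here, one measured step bears on this. It is a 1.1-fold lower number from compound 1 to compound 2 (0.04 log units; within the scatter) and it exchanged 4-methoxyphenyl for 3-(trifluoromethyl)phenyl at that same place. Among the compounds with values here, that single exchange left the value within the scatter, but it is thin evidence, and no measured compound carries a nitro group.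

The expected change is a 1.0-fold higher number from compound 2 to compound 3 (0.00 log units; within the scatter) and no step beyond the scatter is therefore expected in this assay for the new group. Compound 3 is estimated at 38000 nM with an expected range of 19000 nM to 75000 nM in repeat measurements.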

Compound 3, half-maximal inhibitory concentration: 5200 nM
The estimate for compound 3 lay 7.3-fold (0.86 log units) above the measured number; measured number below the stated range.
By their numbers in this assay, from the lowest: compound 3; then compounds 2 and 1 (each within the scatter of the next).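

In this assay the aromatic group on this carbonyl carbon is not a silent position, as the first exchange alone might have suggested: 2-nitrophenyl gives a 7.3-fold lower number from compound 2 to compound 3 (0.86 log units; beyond the scatter) against 3-(trifluoromethyl)phenyl and an 8.0-fold lower number from compound 1 to compound 3 (0.90 log units; beyond the scatter) against 4-methoxyphenyl. Both steps lie beyond the scatter and are of similar size, whereas a 1.1-fold lower number from compound 1 to compound 2 (0.04 log units; within the scatter) stayed within it, so compound 3 stands apart from a level pair and the gain belongs to the 2-nitrophenyl group rather than to a general trend across aryl esters on the shared core. No measured data on any property of these groups accompany the series, so the numbers record the step without accounting for it.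

With a single nitro compound, the series cannot separate the contribution of the nitro group itself from that of its place on the ring, and three aryl groups define no trend. As far as these compounds go, it remains open whether an unsubstituted phenyl, or an amine or a carboxylic acid on the ring in place of the nitro group, would keep the lower number seen for compound 3 at 5200 nM in this assay.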